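Shortening a hexyloxy chain to methoxy in a chalcone-stilbene series

This account rests on a few compounds, and the source may have more. Where it says the series, first, only, none or still open, it means among the compounds named here.

The account concerns two measured compounds and one still to be measured, all sharing one core and tested in a functional assay on B16-F10 cells (Mus musculus) for antiproliferative activity, read by MTT assay, with a stated time of 48 h; a lower number here means a stronger inhibitor, a higher number a weaker inhibitor. Within the data shown here, compound 1 `CCCCCCOc1ccc(C(=O)/C=C/c2c(/C=C/c3ccc(OC)cc3)cc(OC)cc2OC)cc1` carries a hexyloxy group on the ketone-bearing ring; in this assay compound 1 gives 10.4 ug/mL, the highest of the two numbers so far. Compound 2 `COc1ccc(/C=C/c2cc(OC)cc(OC)c2/C=C/C(=O)c2ccccc2C)cc1` is its nearest neighbour: in this assay compound 2 gives 6.1 ug/mL, a number that sits within the usual scatter of that of compound 1, so the two cannot be ranked against each other.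

Compound 3 `COc1ccc(/C=C/c2cc(OC)cc(OC)c2/C=C/C(=O)c2ccc(OC)cc2)cc1` differs from compound 1 in one place: hydrogen in place of pentyl on a saturated chain carbon bound to an oxygen on an aromatic ring. Among the measured compounds shown here, no measured pair in this set isolates that change, so its size is not known from the data. Given that the two measured compounds fall within the scatter of each other, compound 3 is expected to stay close to compound 1, with a step of a 1.3-fold lower number from compound 1 to compound 3 (0.11 log units; within the scatter) that is not expected to exceed the scatter in either direction. Compound 3 is therefore estimated at 8 ug/mL, with a range from 3 ug/mL to 22 ug/mL.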

Compound 3, half-maximal inhibitory concentration: 5.8 ug/mL
Beside the measured number, compound 3's estimate is 1.4-fold (0.14 log units) above it, and the stated range covers the measured number.
By their numbers in this assay, from the lowest: compounds 3, 2 and 1 (each within the scatter of the next).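

Among these compounds, compound 1 and compound 3 form the first measured pair to isolate hydrogen in place of pentyl on a saturated chain carbon bound to an oxygen on an aromatic ring, and in this assay this hexyloxy to methoxy change gives a step that does not exceed the scatter (a 1.8-fold lower number from compound 1 to compound 3 (0.25 log units; within the scatter)). Among the compounds shown here, at this place, therefore, the series tolerates either hexyloxy or methoxy without a resolved difference in the number, which the earlier compounds, differing from each other in more than one place, could not show, and the second new pair adds a comparison on the carbonyl carbon, where 4-methoxyphenyl in place of 2-methylphenyl also leaves the number unresolved (a 1.1-fold lower number from compound 2 to compound 3 (0.02 log units; within the scatter)). No independent measurement offers an explanation for either step.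

The compounds shown leave open whether any group at this place can move the number beyond the scatter, such as a chain longer than hexyl, or a hexyl chain ending in an amine or a carboxylic acid. They also leave open whether the same hexyloxy to methoxy change would remain this small with a group other than the 4-substituted phenyl on the carbonyl carbon.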